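Removing the (carboxymethyl)amino group from compound 3

The source may hold more compounds than are shown below. What is called first, only, known or untested is meant among the compounds shown, and "the series" means these compounds.

For the measured compounds named here, compound 3 `O=C(O)CNc1ccc2ccc(C(=O)c3ccc(F)c(O)c3)nc2c1` is assessed in an assay for binding affinity to 17-beta-hydroxysteroid dehydrogenase 14 (Homo sapiens), read by fluorescence, with a stated time of 15 min, in the presence of a further agent that is not named here (on this read-out lower numbers stand for stronger inhibition and higher numbers for weaker inhibition), where compound 3 gives 23 nM, the lowest of the three numbers so far. Compound 1 `CN(c1ccc(F)c(O)c1)c1cccc(-c2cccc(O)c2F)n1` gives 42 nM in this assay, within the scatter of compound 3, so the two cannot be ordered. Compound 2 `O=C(Nc1ccc(F)c(O)c1)c1cccc(-c2cccc(O)c2F)n1` gives 336 nM in this assay, beyond the scatter above compound 3. Compound 4 `O=C(c1ccc(F)c(O)c1)c1ccc2ccccc2n1` is not yet measured. It differs from compound 3 in one place: hydrogen in place of (carboxymethyl)amino on an aromatic carbon. Going by the values given here, no measured pair shows this change, so its effect is open. Compound 4 is expected to bind less tightly than compound 3, with an estimated step of a 4.8-fold higher number from compound 3 to compound 4 (0.68 log units; beyond the scatter), a moderate loss beyond the scatter. Compound 4 is estimated at 110 nM, within a range of 35 nM to 400 nM.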

Compound 4, inhibition constant: 12 nM
Beside the measured number, compound 4's estimate is 9.2-fold (0.96 log units) above it, and the stated range ends above it.
By their numbers in this assay, from the lowest: compounds 4, 3 and 1 (each within the scatter of the next, the first and the last beyond it); then compound 2.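

In this assay, replacing the (carboxymethyl)amino group with hydrogen gives a 1.9-fold lower number from compound 3 to compound 4 (0.28 log units; within the scatter), so the two compounds cannot be ordered. This aromatic carbon therefore keeps a number of this size with the whole group gone, and the group's presence shows no measurable gain or loss here. No measured evidence bears on this result.

Still open, on these data alone, is whether a simple amine, a carboxylic acid or a longer chain on this carbon would move the number beyond the scatter. As far as these compounds go, whether this tolerance extends to other cores also remains open.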